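The source may report more compounds than this note shows. Statements on the series, on what has been measured and on what is new or still open speak of the compounds shown alone.

Compound 1 `C/C(=N\NC(=O)COc1cccc2ccccc12)c1ccccc1` carries a methyl on its hydrazone carbon; in an ADME assay on HEL cells (Homo sapiens) for cytotoxicity (on this read-out higher numbers stand for lower toxicity in this test and lower numbers for higher toxicity in this test), compound 1 gives 20 ug/mL. Compound 2 `O=C(COc1cccc2ccccc12)N/N=C/c1ccccc1O` gives 20 ug/mL, level with compound 1 at the digits shown, and together they are the lowest of the three numbers; compound 3 `O=C(COc1cccc2ccccc12)N/N=C/c1ccccc1` gives 100 ug/mL, a gap from compound 1 that lies beyond the scatter. Compound 4 `C/C(=N\NC(=O)COc1cccc2ccccc12)c1ccc(O)cc1` differs from compound 1 by hydroxy in place of hydrogen on an aromatic carbon. Going by the values given here, the one step that bears on this is a 5.0-fold higher number from compound 2 to compound 3 (0.70 log units; beyond the scatter), where removing a hydroxy raised the number. Running that change the other way on compound 1, a lower number is expected for compound 4, though compound 1 already sits level with compound 2, so a small step is expected: a 1.3-fold lower number from compound 1 to compound 4 (0.12 log units; within the scatter), giving an estimate of 15 ug/mL with a range from 5 ug/mL to 40 ug/mL.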

Compound 4, minimum cytotoxic concentration: 20 ug/mL
Compound 4: middle estimate off by 1.3-fold (0.12 log units), on the low side; measured number inside the range.
By their numbers in this assay, from the lowest: compounds 1, 2 and 4 (each within the scatter of the next); then compound 3.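

On the core of compound 1, going from phenyl to 4-hydroxyphenyl in this assay gives no change at the digits printed from compound 1 to compound 4 (within the scatter). A hydroxy on the aromatic ring therefore does not lower the number on every core, and the size of this change depends on the compound that carries it: the same change on two cores in this assay, a 5.0-fold higher number (0.70 log units; beyond the scatter) from compound 2 to compound 3 and no change at the digits printed (within the scatter) from compound 4 to compound 1, 5.0-fold (0.70 log units) apart, beyond the scatter of two such steps

The compounds shown do not separate the methyl on the hydrazone carbon from the place of the hydroxy on the ring as the source of that gap. From the compounds shown here alone, how an amine or a carboxylic acid in place of this hydroxy would read also remains open.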